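Halogen to acetamido beside the hydroxy group

This account rests on a few compounds, and the source may have more. Where it says the series, first, only, none or still open, it means among the compounds named here.

Compound 1, `O=C(O)c1cc(-n2c(-c3ccccc3)cc3c2CCCC3)ccc1O`, gives >= 60% in a functional assay on the whole organism (strain Wistar) for inhibition, with Rattus norvegicus as the target, read by paw edema, with stated times of 30 min and 3 h, at a dose of 200 mg/kg by the oral route (a higher number here means more inhibition at the dose given (going by the name of the read-out), a lower number less inhibition), and this is a limit of the assay rather than a number. Compound 2, `O=C(O)c1cc(-n2c(-c3ccccc3)cc3c2CCCC3)cc(Br)c1O`, gives 0% in this assay. Compound 3, `O=C(O)c1cc(-n2c(-c3ccccc3)cc3c2CCCC3)cc(Cl)c1O`, gives 0% in this assay.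

For the measured compounds named here, compound 3 stands level with compound 2, the only measured compound it can be compared with on the same footing; the one further value, that of compound 1, is a limit (the limit of >= 60% in this assay, at which 1 of the 3 values shown sits). The change to compound 4, `CC(=O)Nc1cc(-n2c(-c3ccccc3)cc3c2CCCC3)cc(C(=O)O)c1O`, is acetamido in place of chloro on an aromatic carbon. Going by the values given here, two measured steps bear on the same carbon: a number at least 60 percentage points lower from compound 1 to compound 2 (beyond the scatter) and a number at least 60 percentage points lower from compound 1 to compound 3 (beyond the scatter), both large losses when a halogen enters there, while no change at the digits printed from compound 2 to compound 3 (within the scatter). Among the compounds with values here, no measured step tells what an acetamido group does at this carbon, so compound 4 has no direct precedent; the acetamido group brings a hydrogen-bond donor and acceptor where the halogens brought none. Given that both halogens gave no inhibition, compound 4 is expected to show at most a modest recovery, with a number 20 percentage points higher from compound 3 to compound 4 (beyond the scatter) as the step expected in this assay. Compound 4 is estimated at 20%, between 0% and 55%.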

Compound 4, a percentage reported as inhibition, in the whole organism at one dose (the size of the read-out at that dose, not a potency): 0%
Compound 4: middle estimate off by 20 percentage points, on the high side; the range from low to high includes it.
By their numbers in this assay, from the lowest: compounds 2, 3 and 4 (each within the scatter of the next). At a limit, above all of these: compound 1.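

In this assay, putting acetamido on this carbon gives no change at the digits printed from compound 3 to compound 4 (within the scatter), and likewise no change at the digits printed from compound 2 to compound 4 (within the scatter), so a group with a hydrogen-bond donor and a hydrogen-bond acceptor reads the same as the two halogens, which have neither. Set against hydrogen, acetamido gives a number at least 60 percentage points lower from compound 1 to compound 4 (beyond the scatter), so the large loss on this aromatic carbon, ortho to a hydroxy group, is no longer confined to halogens but holds for all three groups shown there, with none going against it. The value of compound 1 is a limit: the limit of >= 60% in this assay, at which 1 of the 4 values shown sits.

With compound 2, compound 3 and compound 4 reading alike, the compounds shown do not tell whether any substituent on this carbon can keep inhibition, and a fluoro, a methyl, a methoxy or an amine there would test that. They also leave open whether acetamido or a halogen on another carbon of the same ring would bring the same loss, and how any of these compounds would read at a dose other than the single one used.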